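Methoxy Replaces Furan Ester on the Anilide Ring

The source may report more compounds than this note shows. Statements on the series, on what has been measured and on what is new or still open speak of the compounds shown alone.

Compound 1, `O=C(Nc1cccc(CN2CCCC2)c1)C1CCCN(C(=O)c2cc(C(F)(F)F)cc(C(F)(F)F)c2)C1`: 51%
Compound 2, `COC(=O)c1cc(-c2cccc(NC(=O)C3CCCN(C(=O)c4cc(C(F)(F)F)cc(C(F)(F)F)c4)C3)c2)co1`: 0%

In an ADME assay on PC-3 cells (Homo sapiens) for cytotoxicity, read by WST assay, tested at 100 uM (a higher number here means more inhibition at the concentration tested (going by the name of the read-out), a lower number less inhibition), compound 1 gives 51%, while compound 2 gives 0%, the lowest of the two numbers. Among the compounds with values here, the one measured step, a number 51 percentage points lower from compound 1 to compound 2 (beyond the scatter), moved the read-out to its floor. Compound 3, `COc1cccc(NC(=O)C2CCCN(C(=O)c3cc(C(F)(F)F)cc(C(F)(F)F)c3)C2)c1`, has not yet been measured. It differs from compound 2 in one place: methoxy in place of 5-(methoxycarbonyl)furan-3-yl on an aromatic carbon. Within the data shown here, no measured step swaps this furan for a methoxy, so the step from compound 1 to compound 2 bears on it only in that the same position of the core was changed there, and that change was large. Since compound 2 sits at zero, the step to compound 3 is expected to be upward or none beyond the scatter, and is estimated at a number 15 percentage points higher from compound 2 to compound 3 (beyond the scatter). Compound 3 is accordingly expected to give about 15%, within a range from 0% to 45%.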

Compound 3, a percentage reported as inhibition, at one concentration (the size of the read-out at that concentration, not a potency): 0%
Compound 3: middle estimate off by 15 percentage points, on the high side, within the range that was stated.
By their numbers in this assay, from the lowest: compounds 2 and 3 (each within the scatter of the next); then compound 1.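

In this assay, a methoxy group, with no ring, reads no differently from 5-(methoxycarbonyl)furan-3-yl on this aromatic carbon (no change at the digits printed from compound 2 to compound 3 (within the scatter)), so the reading of compound 2 is not peculiar to the furan ester. Replacing (pyrrolidin-1-yl)methyl with methoxy gives the second large step at this position (a number 51 percentage points lower from compound 1 to compound 3 (beyond the scatter)), and among these three compounds only compound 1, which carries the (pyrrolidin-1-yl)methyl group, reads above zero. Nothing available here explains this difference in the readings.

The compounds shown leave open whether the reading of compound 1 depends on the pyrrolidine ring itself or would persist with another amine, such as a dimethylaminomethyl group, on the same aromatic carbon. They also leave open what a carboxylic acid or a longer chain ending in an amine would give there.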